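Aryl swap to 2-fluorophenyl in the bis-arylidene series

The source may hold more compounds than are shown below. What is called first, only, known or untested is meant among the compounds shown, and "the series" means these compounds.

Measured compounds:
compound 1 `C=CCn1c(=O)/c(=C\c2cccc(C)c2)[nH]c(=O)/c1=C\c1ccccc1OC` — 20700 nM
compound 2 `C=CCn1c(=O)/c(=C\c2cccc(F)c2)[nH]c(=O)/c1=C\c1ccccc1OC` — 13700 nM
compound 3 `C=CCn1c(=O)/c(=C\c2ccccc2OC)[nH]c(=O)/c1=C\c1ccccc1OC` — 41100 nM

In a functional assay on MCF7 cells (Homo sapiens) for cytotoxicity, read by CCK-8 assay, with a stated time of 72 h (a higher number here means a weaker inhibitor, a lower number a stronger inhibitor), compound 3 gives the highest of the three numbers. Its gap to compound 2 is printed as beyond the scatter (a 3.0-fold higher number from compound 2 to compound 3 (0.48 log units; beyond the scatter)), while its gap to compound 1 is within it (a 2.0-fold higher number from compound 1 to compound 3 (0.30 log units; within the scatter)). Compound 4 `C=CCn1c(=O)/c(=C\c2ccccc2F)[nH]c(=O)/c1=C\c1ccccc1OC` differs from compound 3 in one place: fluoro in place of methoxy on an aromatic carbon.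

Among the compounds with values here, two measured steps bear on this. Exchanging methyl for fluoro on an aromatic carbon gave a 1.5-fold lower number from compound 1 to compound 2 (0.18 log units; within the scatter), a change that does not leave the scatter. Exchanging a 3-fluorophenyl for the 2-methoxyphenyl gave a 3.0-fold higher number from compound 2 to compound 3 (0.48 log units; beyond the scatter), a modest rise; read in reverse, putting fluorine where methoxy stood is associated with a modest fall, though that step also moves the substituent around the ring, whereas in compound 4 the fluoro sits where the methoxy sat. On these grounds a small lowering of the number is expected, of a size near the scatter edge.

Compound 4 is therefore expected to give an estimate of 20000 nM, with a range of 9000 nM to 45000 nM, which means an expected step of a 2.1-fold lower number from compound 3 to compound 4 (0.31 log units; beyond the scatter).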

Compound 4, half-maximal inhibitory concentration: 23000 nM
Compound 4: middle estimate off by 1.2-fold (0.06 log units), on the low side; the measured number falls inside the stated range.
By their numbers in this assay, from the lowest: compounds 2, 1, 4 and 3 (each within the scatter of the next, the first and the last beyond it).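

In this assay, the direct exchange of methoxy for fluoro on the aromatic carbon ortho to a large group gives a 1.8-fold lower number from compound 3 to compound 4 (0.25 log units; within the scatter), so this change, with no shift of the substituent around the ring, stays inside the scatter. The fluoro compound is also not separated from the other two: 2-fluorophenyl against 3-fluorophenyl gives a 1.7-fold higher number from compound 2 to compound 4 (0.23 log units; within the scatter), and 2-fluorophenyl against 3-methylphenyl gives a 1.1-fold higher number from compound 1 to compound 4 (0.05 log units; within the scatter), so compound 4 cannot be told apart from any of the other three, although compound 2 and compound 3 can be told apart from each other. Nothing at hand gives a reason for these steps.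

Still open, going by these compounds, is whether an amine or a carboxylic acid on this same aromatic carbon would give a step from compound 3 that leaves the scatter, as fluoro does not. Also unsettled is what lies behind the one gap beyond the scatter, a 3.0-fold higher number from compound 2 to compound 3 (0.48 log units; beyond the scatter), since compound 4 falls within the scatter of both compounds and does not assign that gap to the substituent or to its place on the ring.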